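Triazole in place of the nitrile-bearing chain

This account rests on a few compounds, and the source may have more. Where it says the series, first, only, none or still open, it means among the compounds named here.

Measured so far:
compound 1, `C=CCc1cc(C(C)=O)c(O)cc1OCC#N`: 20%
compound 2, `CCc1cc(C(C)=O)c(O)cc1OCCCCCCCC(C)(C)C#N`: 66%
compound 3, `CCCc1cc(C(C)=O)c(O)cc1OCCCCCC(=O)O`: 73%

In an assay on isolated protein for inhibition of leukotriene B4 receptor 1 (Homo sapiens), tested at 10 uM (a lower number here means less inhibition, a higher number more inhibition at the concentration tested (going by the name of the read-out)), compound 1 gives 20%, compound 2 gives 66% and compound 3 gives 73%. Compound 2 holds the second highest of the three numbers. Its nearest neighbour is compound 3, a little higher but within the scatter, so no order between the two can be read. Compound 1 lies far below, well beyond the scatter; of that gap only the two values themselves speak, as the pair differs in more than one place.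

Compound 4, `CCc1cc(C(C)=O)c(O)cc1OCCCCCn1cncn1`, is the next candidate. It differs from compound 2 as follows: 1H-1,2,4-triazol-1-yl in place of 3-cyano-3-methylbutyl on a saturated chain carbon, five bonds along the chain from an oxygen on an aromatic ring. Among the compounds with values here, no single-point step between measured compounds is at hand to calibrate this change. The expectation is a moderate fall from compound 2 to compound 4, estimated at a number 16 percentage points lower from compound 2 to compound 4 (beyond the scatter), which would carry it just past the scatter. For compound 4 the estimated value in this assay is 50%, expected within 25% to 75%.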

Compound 4, a percentage reported as inhibition, at one concentration (the size of the read-out at that concentration, not a potency): 82%
Compound 4: middle estimate off by 32 percentage points, on the low side, outside the stated range (above it).
By their numbers in this assay, from the lowest: compound 1; then compounds 2, 3 and 4 (each within the scatter of the next, the first and the last beyond it).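

In this assay, within the data shown here, 1H-1,2,4-triazol-1-yl in place of 3-cyano-3-methylbutyl, on a saturated chain carbon, five bonds along the chain from an oxygen on an aromatic ring, gives a number 16 percentage points higher from compound 2 to compound 4 (beyond the scatter), the only single-place step so far. This position therefore accepts a five-membered aromatic ring with 3 hetero atoms in place of a ringless, nitrile-bearing group, with no loss of inhibition at the concentration tested. Nothing at hand bears on why the number rises.

On these data alone, whether the gain belongs to the triazole itself remains open: an imidazole, a tetrazole or a primary amine at the same place on the core of compound 4 would test this. A reading at one concentration also leaves the potency of compound 4 open.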